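The source may report more compounds than this note shows. Statements on the series, on what has been measured and on what is new or still open speak of the compounds shown alone.

Measured in an ADME assay on the whole organism with Oryza sativa as the target, tested at 0.1 uM; on this read-out lower numbers stand for a stronger effect and higher numbers for a weaker effect at the one concentration tested:

compound 1 `CCCCc1ccc(NC(=O)N[C@H](C)c2ccccc2)cc1` – 100%
compound 2 `CCCCCc1ccc(NC(=O)N[C@H](C)c2ccccc2)cc1` – 100%
compound 3 `CCCCCCc1ccc(NC(=O)N[C@H](C)c2ccccc2)cc1` – 100%

Compound 3 stands level with compounds 1 and 2 in this assay; the chain-lengthening steps no change at the digits printed from compound 1 to compound 2 (within the scatter), no change at the digits printed from compound 1 to compound 3 (within the scatter) and no change at the digits printed from compound 2 to compound 3 (within the scatter) all leave the reading where it was. Each of these three compounds reads at the top of the scale, which on this read-out is the weakest effect the assay reports.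

Compound 4 `CC(=O)c1ccc(NC(=O)N[C@H](C)c2ccccc2)cc1` is the next member. It differs from compound 3 by acetyl in place of hexyl on an aromatic carbon.

Among the measured compounds shown here, none of the measured steps exchanges the chain for an acetyl group; they only vary the length of the chain, and each of them is within the scatter. For the measured compounds named here, there is therefore no direct precedent for the step to compound 4, and the expectation rests only on the uniform reading of compounds 1, 2 and 3. On that basis compound 4 is expected to stay near the same reading, with a wider range to allow for the different kind of change. Compound 4 is estimated at 97%, in a range from 75% to 100%. This estimate means an expected step of a number 3 percentage points lower from compound 3 to compound 4 (within the scatter), within the scatter.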

Compound 4, a percentage reported as activity, at one concentration (the size of the read-out at that concentration, not a potency): 96%
Compound 4: the middle estimate sits 1 percentage points above what was measured; the measured number falls inside the stated range.
By their numbers in this assay, from the lowest: compounds 4, 1, 2 and 3 (each within the scatter of the next).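

In this assay, among the compounds shown here, the earlier compounds varied only chain length, whereas this step exchanges the chain for acetyl on an aromatic carbon para to a large group, bringing in a carbonyl and a hydrogen-bond acceptor with fewer heavy atoms. The result is a number 4 percentage points lower from compound 3 to compound 4 (within the scatter), and the shorter chains give a number 4 percentage points lower from compound 2 to compound 4 (within the scatter) and a number 4 percentage points lower from compound 1 to compound 4 (within the scatter), so at this position the reading stays within the scatter across a change in the kind of group as well as in chain length. No available evidence bears on why the reading holds across this exchange.

Still open, as far as these compounds go, is whether any group at this aromatic carbon moves the reading beyond the scatter, for example a carboxylic acid or an amine. The compounds shown also leave open whether changes elsewhere on the shared core would do so.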